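Two-ring core imine series: half-life in mouse microsomes

The compounds below may be only part of what the source reports. "The series", "measured", "known", "first", "only" and "open" are said of these compounds alone.

Measured so far:
- Compound 1 `N=c1c2c(-c3ccccc3)c(-c3ccccc3)n(Cc3ccccc3)c2ncn1CCCN1CCN(c2ccccc2)CC1`: 0.233 h
- Compound 2 `COc1ccc(-c2c(-c3ccc(OC)cc3)n(Cc3ccccc3)c3ncn(CCO)c(=N)c23)cc1`: 1.22 h

In an ADME assay on microsomes from liver (Mus musculus, strain CD1) for metabolic stability, read by LC-MS, using NADPH, with a stated time of 60 min (on this read-out lower numbers stand for a shorter-lived compound and higher numbers for a longer-lived compound), compound 2 gives 1.22 h, the higher of the two numbers; compound 1 gives 0.233 h, and the gap between the two lies beyond the usual scatter. Compound 3 `COc1ccc(-c2c(-c3ccc(OC)cc3)n(Cc3ccccc3)c3ncn(C4CCOCC4)c(=N)c23)cc1` has not yet been measured. It differs from compound 2 in one place: oxan-4-yl in place of 2-hydroxyethyl on an aromatic nitrogen. Within the data shown here, no step of this kind has been measured here, so the direction is open; the step from compound 2 to compound 3 is expected to be a 1.2-fold lower number from compound 2 to compound 3 (0.09 log units; within the scatter), that is, likely within the scatter. Compound 3 is expected to give about 1 h in this assay, with a range from 0.4 h to 2.5 h.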

Compound 3, half-life: 0.978 h
The estimate for compound 3 lay 1.0-fold (0.01 log units) above the measured number, within the range that was stated.
By their numbers in this assay, from the lowest: compound 1; then compounds 3 and 2 (each within the scatter of the next).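

In this assay, putting oxan-4-yl in place of 2-hydroxyethyl on the aromatic nitrogen gives a 1.2-fold lower number from compound 2 to compound 3 (0.10 log units; within the scatter). At this position, then, the half-life stays in the same range even though a six-membered non-aromatic ring enters, the heavy-atom count grows and the hydrogen-bond donor of 2-hydroxyethyl leaves. Nothing measured here explains this result. As far as these compounds go, what an amine, a carboxylic acid or a longer chain on this nitrogen would do to the half-life remains open. From the compounds shown here alone, whether the same swap would behave alike on the core of compound 1 also remains open.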